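This account rests on a few compounds, and the source may have more. Where it says the series, first, only, none or still open, it means among the compounds named here.

Measured so far in this series:
- compound 1 `COc1c(Cl)cccc1-n1c(C)cc(C(=O)O)c1C`, giving 800 nM
- compound 2 `Cc1cc(C(=O)O)c(C)n1-c1ccc(F)cc1`, giving 1900 nM
- compound 3 `Cc1cc(C(=O)O)c(C)n1-c1c(Cl)cccc1Cl`, giving 2300 nM

All three numbers come from an assay on cells for inhibition of Palmitoleoyl-protein carboxylesterase NOTUM variant C330S (Homo sapiens), read by fluorescence, with a stated time of 40 min; on this read-out higher numbers stand for weaker inhibition and lower numbers for stronger inhibition. On this read-out compound 1 stands lowest of the three, and both gaps lie beyond the usual scatter: compound 2 sits well above it, compound 3 further still. Going by the values given here, compounds 2 and 3 carry only halogens on the phenyl ring; compound 1 is the sole member with a methoxy, and the only one with a substituent pattern of this kind, so no single-change comparison exists among the measured compounds.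

Compound 4 `Cc1cc(C(=O)O)c(C)n1-c1cccc(Cl)c1F` has not been measured. Relative to compound 1 the change is fluoro in place of methoxy on an aromatic carbon. Among the compounds with values here, no measured pair isolates this change, so the expected step rests on the broader picture: the two halogen-only analogues, compound 2 and compound 3, both gave higher numbers than compound 1, while the change itself is small in atom count. The step from compound 1 to compound 4 is expected to be modest, toward a higher number, and perhaps not beyond the scatter; the estimate is a 1.6-fold higher number from compound 1 to compound 4 (0.21 log units; within the scatter). On this basis compound 4 is expected to give about 1300 nM in this assay, with a likely range from 450 nM to 3800 nM.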

Compound 4, half-maximal inhibitory concentration: 380 nM
Beside the measured number, compound 4's estimate is 3.4-fold (0.53 log units) above it, outside the stated range (below it).
By their numbers in this assay, from the lowest: compound 4; then compound 1; then compounds 2 and 3 (each within the scatter of the next).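

In this assay, going by these compounds alone, fluoro in place of methoxy, ortho to a chloro group, gives a 2.1-fold lower number from compound 1 to compound 4 (0.32 log units; beyond the scatter), a modest step beyond the scatter and the first single-change comparison. A low number at this position therefore does not depend on the methoxy: the smaller fluoro, with no hydrogen-bond acceptor counted for it, gives a lower number on the same core. No measurement at hand accounts for this step.

A single pair cannot separate a contribution of the fluoro from the loss of the methoxy, and an amine or a nitrile at this same position would test how much the group's identity matters. Also open, as far as these compounds go, is whether the step would hold without the neighbouring chloro group.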